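The source may report more compounds than this note shows. Statements on the series, on what has been measured and on what is new or still open speak of the compounds shown alone.

Measured in a physicochemical assay for solubility, read by spectrophotometry, in phosphate buffer, with a stated time of 2 h, at pH 7.4; a lower number here means a less soluble compound, a higher number a more soluble compound: compound 1 `COc1cccc(CN2C(=O)CN(C(=O)c3cc4cc(OC)ccc4[nH]3)C[C@@H]2COCc2ccccc2)c1` gives 11700 nM. Compound 2 `COc1ccc2[nH]c(C(=O)N3CC(=O)N(Cc4ccccc4)[C@@H](CN4CCCC4)C3)cc2c1` is reported only as a limit, > 25000 nM, in this assay.

Compound 2 therefore stands at the limit of > 25000 nM in this assay, at which 1 of the 2 values shown sits; its true position on the numbers is not known beyond that limit. Compound 3 `COc1ccc2[nH]c(C(=O)N3CC(=O)N(Cc4ccccc4)[C@@H](CN4CC5CCCC5C4)C3)cc2c1` differs from compound 2 by a group of 8 heavy atoms (7 carbon, 1 nitrogen; one five-membered non-aromatic ring of carbon only, one five-membered non-aromatic ring with 1 hetero atom) in place of a group of 5 heavy atoms (4 carbon, 1 nitrogen; one five-membered non-aromatic ring with 1 hetero atom), on a saturated chain carbon bound to a saturated ring carbon. Going by the values given here, no measured step matches this change, so no direct guide exists. A modest decrease in this assay is expected, probably not far beyond the usual scatter, as the step of an at least 1.7-fold lower number from compound 2 to compound 3 (0.25 log units; that floor lies within the scatter). Compound 3 is accordingly estimated at 14000 nM, with a range from 5000 nM to 30000 nM.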

Compound 3, solubility: 20700 nM
Estimate against measurement, compound 3: 1.5-fold (0.17 log units) below; measured number inside the range.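

Going by these compounds alone, this is the first measured change on a saturated chain carbon bound to a saturated ring carbon: in this assay, replacing pyrrolidin-1-yl with the group that adds a five-membered ring of carbon only gives an at least 1.2-fold lower number from compound 2 to compound 3 (0.08 log units; that floor lies within the scatter). With that group in place, compound 3 gives 20700 nM, a number rather than a limit. Compound 2 carries only a limit, so the true size of this step remains unknown: the limit of > 25000 nM in this assay, at which 1 of the 3 values shown sits.

As far as these compounds go, whether a morpholine or a carboxylic acid at this place would give a different number remains open. So does whether a smaller amine, such as dimethylamino, would give a reading or another limit.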